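A few compounds are considered here, and "the series" means these few. Any claim that something is new, unique, unknown or untested is made for them only; others in the source may bear on it.

Compound 3 `COc1ccc(C(=O)/C=C/c2cc(-c3cc(OC)c(OC)c(OC)c3)n[nH]2)cc1` has the lowest number of the three compounds measured in a functional assay on SK-MEL-5 cells (Homo sapiens) for inhibition, read by sulforhodamine B assay, with a stated time of 48 h (a lower number here means a stronger inhibitor of growth, a higher number a weaker inhibitor of growth), at 3240 nM. Compound 1 `COc1ccc(-c2cc(/C=C/C(=O)c3ccc(OC)c(OC)c3)[nH]n2)cc1` stands nearest to it, with 3720 nM, a gap that lies within the scatter, so no order between the two can be claimed. Compound 2 `COc1cc(-c2cc(/C=C/C(=O)c3ccc(Cl)c(Cl)c3)[nH]n2)cc(OC)c1OC` lies furthest away, at 46900 nM. Among the measured compounds shown here, the one measured step that bears on the present question is a 14-fold lower number from compound 2 to compound 3 (1.16 log units; beyond the scatter), a change at the same place as the one now considered. Compound 4 `COc1cc(-c2cc(/C=C/C(=O)c3ccc(F)c(F)c3)[nH]n2)cc(OC)c1OC` differs from compound 3 in one place: 3,4-difluorophenyl in place of 4-methoxyphenyl on a carbonyl carbon. This move again replaces 4-methoxyphenyl with a dihalogenated phenyl on the carbonyl carbon, so compound 4 is expected to give a higher number than compound 3, because the earlier dihalogenated analogue compound 2 gave 46900 nM. The step is estimated as a 6.2-fold higher number from compound 3 to compound 4 (0.79 log units; beyond the scatter), probably somewhat smaller than the dichloro step but beyond the scatter. Compound 4 is therefore estimated at 20000 nM, within a range from 6000 nM to 60000 nM.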

Compound 4, concentration for total growth inhibition: 6410 nM
Estimate against measurement, compound 4: 3.1-fold (0.49 log units) above; measured number inside the range.
By their numbers in this assay, from the lowest: compounds 3, 1 and 4 (each within the scatter of the next); then compound 2.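

In this assay, among the compounds shown here, the step of a 2.0-fold higher number from compound 3 to compound 4 (0.30 log units; within the scatter) lies within the scatter, so 3,4-difluorophenyl and 4-methoxyphenyl on the carbonyl carbon cannot be told apart, and a dihalogenated phenyl at this place does not by itself bring the large step of a 14-fold lower number from compound 2 to compound 3 (1.16 log units; beyond the scatter) from the earlier compounds. The step of a 7.3-fold lower number from compound 2 to compound 4 (0.86 log units; beyond the scatter) separates the two dihalogenated groups, so among these compounds the high number of compound 2 goes with 3,4-dichlorophenyl and not with 3,4-difluorophenyl. No measurement shown here accounts for this difference between the two groups.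

The compounds shown leave open whether a phenyl carrying a single fluorine or chlorine would stand with compound 4 or with compound 2. They also do not tell how an amine or a carboxylic acid on this phenyl would fare at the same place.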